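This account rests on a few compounds, and the source may have more. Where it says the series, first, only, none or still open, it means among the compounds named here.

Working notes on the series. All three measured compounds sit at the ceiling of the cytotoxicity read-out. Compound 3 `Cc1nc(N)c2c(-c3ccsc3)cn([C@@H]3O[C@H](CO)[C@@H](O)[C@H]3O)c2n1` returns only a limit in an ADME assay on MRC5 cells (Homo sapiens), read by MTT assay, with a stated time of 72 h (on this read-out lower numbers stand for stronger inhibition and higher numbers for weaker inhibition), namely > 100000 nM. Compound 1 `Cc1nc(N)c2c(-c3ccoc3)cn([C@@H]3O[C@H](CO)[C@@H](O)[C@H]3O)c2n1` likewise returns only a limit in this assay, > 100000 nM. Compound 2 `CNc1ncnc2c1c(-c1ccsc1)cn2[C@@H]1O[C@H](CO)[C@@H](O)[C@H]1O` also gives only a limit in this assay, > 100000 nM. The change from compound 3 to compound 1, (furan-3-yl in place of thiophen-3-yl on an aromatic carbon), made a step that the two limits leave unreadable from compound 3 to compound 1, since both values sit at the limit of > 100000 nM in this assay, at which 3 of the 3 values shown sit. Compound 2 and compound 3 share the same atoms joined differently; the difference between the two cores is not broken down here. Compound 4 `CNc1ncnc2c1c(-c1ccoc1)cn2[C@@H]1O[C@H](CO)[C@@H](O)[C@H]1O` is not yet measured; it carries the same kind of change, (furan-3-yl in place of thiophen-3-yl on an aromatic carbon), with the place described in identical words. On the strength of the limit of > 100000 nM in this assay, at which 3 of the 3 values shown sit, where compound 3 and compound 1 sit, the expected step is a step that the limit leaves unreadable from compound 2 to compound 4. Compound 4 is therefore expected to give 150000 nM in this assay, most probably again only a limit.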

Compound 4, half-maximal inhibitory concentration: > 100000 nM
Compound 4 gave a limit, no number (the forecaster's own chance of this, stated with the estimate: 85%); the middle value is on the limit's open side.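

No step can be read from compound 2 to compound 4, because both give only a limit in this assay: the limit of > 100000 nM in this assay, at which 4 of the 4 values shown sit.

The compounds shown leave open whether furan-3-yl in place of thiophen-3-yl changes this read-out at all.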